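Aryl exchange on the ring nitrogen: outlook for compound 3

The source may report more compounds than this note shows. Statements on the series, on what has been measured and on what is new or still open speak of the compounds shown alone.

compound 1 `Cn1ccc2c(Oc3ccc(NC(=O)c4cc5cccnc5n(-c5ccc(F)c(Cl)c5)c4=O)cc3F)ccnc21`: 2460 nM in a functional assay on HT-29 cells (Homo sapiens) for antiproliferative activity, read by MTT assay, with a stated time of 72 h; on this read-out higher numbers stand for weaker inhibition and lower numbers for stronger inhibition
compound 2 `Cn1ccc2c(Oc3ccc(NC(=O)c4cc5cccnc5n(-c5ccc(Br)cc5F)c4=O)cc3F)ccnc21`: 3290 nM

On these two numbers compound 2 stands beside compound 1 within the scatter; the pair cannot be ordered. Compound 3 `Cn1ccc2c(Oc3ccc(NC(=O)c4cc5cccnc5n(-c5ccc(C(F)(F)F)cc5Cl)c4=O)cc3F)ccnc21` differs from compound 2 by 2-chloro-4-(trifluoromethyl)phenyl in place of 4-bromo-2-fluorophenyl on an aromatic nitrogen. Within the data shown here, the one measured step, a 1.3-fold higher number from compound 1 to compound 2 (0.13 log units; within the scatter), also exchanged the aryl group on the same aromatic nitrogen and stayed within the scatter. For compound 3 no step beyond the scatter is therefore expected in this assay, that is a 1.1-fold lower number from compound 2 to compound 3 (0.04 log units; within the scatter). Compound 3 is estimated at 3000 nM, with a range from 1200 nM to 7500 nM.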

Compound 3, half-maximal inhibitory concentration: 5830 nM
Compound 3: middle estimate off by 1.9-fold (0.29 log units), on the low side; the range from low to high includes it.
By their numbers in this assay, from the lowest: compounds 1, 2 and 3 (each within the scatter of the next, the first and the last beyond it).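

In this assay the aryl group on this aromatic nitrogen now gives its first step beyond the scatter, a modest one, with 2-chloro-4-(trifluoromethyl)phenyl in place of 3-chloro-4-fluorophenyl (a 2.4-fold higher number from compound 1 to compound 3 (0.37 log units; beyond the scatter)). Against 4-bromo-2-fluorophenyl the same group stays within the scatter (a 1.8-fold higher number from compound 2 to compound 3 (0.25 log units; within the scatter)), so the three aryl groups shown span a narrow band. Nothing at hand bears on the reason for either step.

Open, as far as these compounds go, is whether an aryl group carrying an amine or a carboxylic acid, or a benzyl group or longer alkyl chain on this nitrogen, would leave that band.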